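Swapping the Ring on a Shared Core

This account rests on a few compounds, and the source may have more. Where it says the series, first, only, none or still open, it means among the compounds named here.

Three compounds share one core and differ only in the ring attached to a double-bonded chain carbon bound to a double-bonded ring carbon. In a functional assay on A549 cells (Homo sapiens) for inhibition, read by MTT assay, with a stated time of 72 h, tested at 10 uM (a higher number here means more inhibition at the concentration tested (going by the name of the read-out), a lower number less inhibition), compound 1 `CCOC(=O)C1=C(Nc2ccccc2)S/C(=C\c2ccc(OC)cc2)C1=O` gives 17.5%. Compound 2 `CCOC(=O)C1=C(Nc2ccccc2)S/C(=C\c2ccc(Br)c(O)c2)C1=O` gives 13.6%, and compound 3 `CCOC(=O)C1=C(Nc2ccccc2)S/C(=C\c2ccc[nH]2)C1=O` gives 23.5%. Compound 3 thus has the highest of the three numbers, yet the step of a number 6 percentage points higher from compound 1 to compound 3 (within the scatter) and the step of a number 9.9 percentage points higher from compound 2 to compound 3 (within the scatter) both stay within the scatter, as does a number 3.9 percentage points lower from compound 1 to compound 2 (within the scatter), so the three compounds cannot be told apart on these data.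

Compound 4 `CCOC(=O)C1=C(Nc2ccccc2)S/C(=C\c2cccnc2)C1=O` is not yet measured. It differs from compound 3 in one place: pyridin-3-yl in place of 1H-pyrrol-2-yl on a double-bonded chain carbon bound to a double-bonded ring carbon. Within the data shown here, the steps that bear on this change are the three already seen, each of which swaps the ring in the same place, and each of which stays within the scatter. Nothing among them suggests that a further swap of this ring would move the number beyond the scatter. The step of a number 5.5 percentage points lower from compound 3 to compound 4 (within the scatter) is therefore expected to be small. Compound 4 is estimated to give 18%, with a range from 8% to 30%.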

Compound 4, a percentage reported as inhibition, at one concentration (the size of the read-out at that concentration, not a potency): < 10%
Compound 4 gave a limit, no number; the forecaster's own chance of this, stated with the estimate: 0%; middle value at least 8 percentage points away from the limit.
By their numbers in this assay, from the lowest: compounds 2, 1 and 3 (each within the scatter of the next). At a limit, below all of these: compound 4.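

At this place, on a double-bonded chain carbon bound to a double-bonded ring carbon, the earlier ring swaps in this assay all stayed within the scatter, whereas pyridin-3-yl in place of 1H-pyrrol-2-yl gives a number at least 13.5 percentage points lower from compound 3 to compound 4 (beyond the scatter), so the choice of ring here can make a real difference. The other two new comparisons give only floors, a number at least 3.6 percentage points lower from compound 2 to compound 4 (that floor lies within the scatter) and a number at least 7.5 percentage points lower from compound 1 to compound 4 (that floor lies within the scatter), so on these data compound 4 cannot be separated from either of those two compounds. The reading for compound 4 is a limit of the assay and not a number: the limit of < 10% in this assay, at which 1 of the 4 values shown sits.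

The compounds shown leave open whether the ring size or the swap of a hydrogen-bond donor for a hydrogen-bond acceptor separates compound 3 from compound 4, and how far the true value of compound 4 lies under its limit. They also leave open what a group other than an aromatic ring, such as a carboxylic acid or a simple amine on a short chain, would give at this place.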